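Thiophen-2-yl for 3-Methoxyphenyl: What the Data Allow

This account rests on a few compounds, and the source may have more. Where it says the series, first, only, none or still open, it means among the compounds named here.

Compound 1 `CSc1ccc(C2=NN(C(=S)Nc3ccccc3)C(c3ccc4c(c3)OCCO4)C2)cc1`: 159000 nM
Compound 2 `COc1cccc(C2=NN(C(=S)Nc3ccccc3)C(c3ccc4c(c3)OCCO4)C2)c1`: 520 nM

In a functional assay on A-375 cells (Homo sapiens) for antiproliferative activity, read by MTT assay, with a stated time of 48 h (a higher number here means a weaker inhibitor of growth, a lower number a stronger inhibitor of growth), compound 2 gives 520 nM, the lowest of the two numbers shown; its only neighbour is compound 1, and the sole measured step, a 310-fold lower number from compound 1 to compound 2 (2.49 log units; beyond the scatter), is large. Compound 3 `S=C(Nc1ccccc1)N1N=C(c2cccs2)CC1c1ccc2c(c1)OCCO2` differs from compound 2 by thiophen-2-yl in place of 3-methoxyphenyl on a carbon with a double bond to nitrogen. For the measured compounds named here, no measured step touches thiophen-2-yl, so that single step shows only that a change at this carbon can move the number far. Compound 3 is therefore expected to lose some ground, by about a 3.8-fold higher number from compound 2 to compound 3 (0.59 log units; beyond the scatter), with a wide range: the estimate is 2000 nM, between 400 nM and 15000 nM.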

Compound 3, concentration for 50% growth inhibition: 121000 nM
The estimate for compound 3 lay 61-fold (1.78 log units) below the measured number; the whole stated range lies below it.
By their numbers in this assay, from the lowest: compound 2; then compounds 3 and 1 (each within the scatter of the next).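

Thiophen-2-yl on this carbon gives up what 3-methoxyphenyl held (a 230-fold higher number from compound 2 to compound 3 (2.37 log units; beyond the scatter)), so a second replacement at this carbon does not keep the low number of compound 2. Set against 4-(methylsulfanyl)phenyl, thiophen-2-yl shows no separable change (a 1.3-fold lower number from compound 1 to compound 3 (0.12 log units; within the scatter)), which leaves compound 2 alone at the low end of the three. Nothing at hand gives a reason for this.

Still open, from the compounds shown here alone, is whether the low number of compound 2 follows the methoxy group itself or its place on the ring. A 3-hydroxyphenyl or 3-aminophenyl group on this carbon would speak to that.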